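The source may report more compounds than this note shows. Statements on the series, on what has been measured and on what is new or still open speak of the compounds shown alone.

Measured compounds in an ADME assay on MT4 cells (Homo sapiens) for cytotoxicity, read by MTT assay, with a stated time of 5 days; a higher number here means that more compound is tolerated, a lower number that less compound is tolerated:
- compound 1 `CCOC(=O)Cn1cc(CNC(=O)c2cnc(Nc3ccc(C#N)cc3)cc2Oc2c(C)cc(C)cc2C)nn1`: 9530 nM
- compound 2 `Cc1cc(C)c(Oc2cc(Nc3ccc(C#N)cc3)ncc2C(=O)NCc2cn(Cc3ccccc3C#N)nn2)c(C)c1`: > 219000 nM
- compound 3 `Cc1cc(C)c(Oc2cc(Nc3ccc(C#N)cc3)ncc2C(=O)NCc2cn(Cc3ccc(F)cc3)nn2)c(C)c1`: >= 153000 nM

The value of compound 2 is a limit of this assay, not a number (the limit of > 219000 nM in this assay, at which 1 of the 3 values shown sits). The value of compound 3 is likewise a limit (the limit of >= 153000 nM in this assay, at which 1 of the 3 values shown sits). Compound 2 therefore stands only as a limit, and one of the two other values shown is also a limit; only compound 1 gives a number.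

Compound 4 `Cc1cc(C)c(Oc2cc(Nc3ccc(C#N)cc3)ncc2C(=O)NCc2cn(CCCO)nn2)c(C)c1` differs from compound 2 in one place: 2-hydroxyethyl in place of 2-cyanophenyl on a saturated chain carbon bound to an aromatic nitrogen.

Going by the values given here, two measured steps bear on this change, both starting from the ethoxycarbonyl compound: an at least 22-fold higher number from compound 1 to compound 2 (1.36 log units; beyond the scatter) and an at least 16-fold higher number from compound 1 to compound 3 (1.20 log units; beyond the scatter). The step between the two aryl compounds is not readable: a step that the two limits leave unreadable from compound 2 to compound 3. Both readable steps show that replacing ethoxycarbonyl with an aryl group gives a large rise. Compound 4 carries a short hydroxy-bearing chain rather than an aryl group, so the step expected for compound 4 is estimated as an at least 3.6-fold lower number from compound 2 to compound 4 (0.56 log units; beyond the scatter). Compound 4 is estimated at 60000 nM, within 10000 nM to 300000 nM.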

Compound 4, half-maximal cytotoxic concentration: 25200 nM
The estimate for compound 4 lay 2.4-fold (0.38 log units) above the measured number; low and high end bracket the measured number.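

In this assay, going by these compounds alone, the 3-hydroxypropyl group gives the first comparison at this place with a number at both ends, and it shows only a 2.6-fold higher number from compound 1 to compound 4 (0.42 log units; beyond the scatter). Against the aryl-bearing compounds, the same group gives an at least 8.6-fold lower number from compound 2 to compound 4 (0.93 log units; beyond the scatter) and an at least 6.0-fold lower number from compound 3 to compound 4 (0.78 log units; beyond the scatter), so a high tolerated concentration is not shared by every replacement of ethoxycarbonyl and is so far seen only with the two benzyl-type groups. Compound 2 and compound 3 stand only as limits, so these two steps are minimums and the step between those compounds cannot be read.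

The compounds shown do not separate loss of the aromatic ring from arrival of the hydroxyl. A plain propyl chain, a 3-aminopropyl chain or a carboxylic acid at this place would bear on that question.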